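Adding a Phenyl Beyond the Ring of Compound 2

This account rests on a few compounds, and the source may have more. Where it says the series, first, only, none or still open, it means among the compounds named here.

Of the compounds shown here, two built on a shared core have been tested in an ADME assay on HeLa cells (Homo sapiens) for cytotoxicity; a lower number here means a stronger inhibitor, a higher number a weaker inhibitor. Compound 1, `Cc1ncc([N+](=O)[O-])n1CCSC(=S)N1CCC2(CC1)OCCO2`, gives > 1000 ug/mL in this assay, which is a limit of the assay rather than a number. Among the compounds with values here, compound 2, `Cc1ncc([N+](=O)[O-])n1CCSC(=S)N1CCC(C)CC1`, gives 190 ug/mL in this assay, and this is the only number among the two results; the remaining result, that of compound 1, sits at the limit of > 1000 ug/mL in this assay, at which 1 of the 2 values shown sits. Within the data shown here, because only one number exists, no step between measured compounds can be read, and compound 2 stands alone as the sole point of reference.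

Compound 3, `Cc1ncc([N+](=O)[O-])n1CCSC(=S)N1CCC(Cc2ccccc2)CC1`, has not yet been tested in this assay. It differs from compound 2 by phenyl in place of hydrogen on a saturated chain carbon bound to a saturated ring carbon; cut one bond further out, the change reads as methyl to benzyl. Among the measured compounds shown here, with no measured step to lean on, a modest shift toward a lower number in this assay is expected, roughly a step of a 1.9-fold lower number from compound 2 to compound 3 (0.28 log units; within the scatter) from compound 2, though a result within the scatter would not surprise. Compound 3 is therefore estimated at 100 ug/mL in this assay, with a range from 40 ug/mL to 250 ug/mL.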

Compound 3, half-maximal inhibitory concentration: > 1000 ug/mL
Compound 3: only a limit was reported; the forecaster's own chance of this, stated with the estimate: 5%; middle value at least 10-fold (1.00 log units) from the limit.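

The earlier compounds shown here offered no step at all, and this change supplies the first one that can be read at this position. In this assay, phenyl in place of hydrogen on a saturated chain carbon bound to a saturated ring carbon, the change that also reads as methyl to benzyl, gives an at least 5.2-fold higher number from compound 2 to compound 3 (0.72 log units; beyond the scatter), so this place on the shared core does respond to what it carries, and the direction runs opposite to a stronger inhibitor. The value of compound 3, > 1000 ug/mL, is a limit of the assay and not a number, and the single number in the set remains that of compound 2, with the other results gathered at one ceiling: the limit of > 1000 ug/mL in this assay, at which 2 of the 3 values shown sit.

On these data alone, how far past that limit compound 3 lies cannot be told, so the full size of the step remains unknown. As far as these compounds go, it also remains open whether a longer chain in place of the phenyl, or an amine or a carboxylic acid carried on it, would return a number in this assay or would stay at the limit.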